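Furan-3-yl for phenyl on the shared core

The compounds below may be only part of what the source reports. "The series", "measured", "known", "first", "only" and "open" are said of these compounds alone.

compound 1 `Cc1ncnc2c1c(-c1ccoc1)cn2[C@@H]1O[C@H](CO)[C@@H](O)[C@H]1O` — in a functional assay on CEM-DNR-bulk cells (Homo sapiens), read by MTT assay, with a stated time of 72 h (a lower number here means a stronger inhibitor, a higher number a weaker inhibitor), compound 1 gives > 20000 nM, a limit of the assay.
compound 2 `C#Cc1cn([C@@H]2O[C@H](CO)[C@@H](O)[C@H]2O)c2ncnc(NC)c12` — in this assay compound 2 gives 18500 nM.
compound 3 `CNc1ncnc2c1c(-c1ccccc1)cn2[C@@H]1O[C@H](CO)[C@@H](O)[C@H]1O` — in this assay compound 3 gives > 20000 nM, a limit of the assay.

Compound 3 stands at a limit, not at a number: its value is the limit of > 20000 nM in this assay, at which 2 of the 3 values shown sit. Going by the values given here, compound 2 is the only measured compound with a number. Among the compounds with values here, the single measured step, an at least 1.0-fold higher number from compound 2 to compound 3 (0.03 log units; that floor lies within the scatter), is a floor within the scatter, so it shows no more than that compound 3 is not a stronger inhibitor than compound 2.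

Compound 4 `CNc1ncnc2c1c(-c1ccoc1)cn2[C@@H]1O[C@H](CO)[C@@H](O)[C@H]1O` is not yet measured. It differs from compound 3 in one place: furan-3-yl in place of phenyl on an aromatic carbon. Within the data shown here, no measured step covers this exchange. Among the measured compounds shown here, compound 1 also bears furan-3-yl, but differs from compound 4 in a second place as well, so it gives no direct step. With nothing measured to move it off the limit, the expectation is that compound 4 stays at or near the limit, with no step beyond the scatter. The step expected is a step that the limit leaves unreadable from compound 3 to compound 4. In this assay compound 4 is estimated at 22000 nM, within 9000 nM to 55000 nM.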

Compound 4, half-maximal inhibitory concentration: > 20000 nM
Compound 4: a limit, no number; the forecaster's own chance of this, stated with the estimate: 75%; the middle value does not contradict the limit.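

Furan-3-yl on this aromatic carbon, like phenyl, leaves the methylamino compound at the limit in this assay: the limit of > 20000 nM in this assay, at which 3 of the 4 values shown sit.

Furan-3-yl in place of ethynyl gives an at least 1.0-fold higher number from compound 2 to compound 4 (0.03 log units; that floor lies within the scatter), so this one readable step shows only that the furan-3-yl compound is not a stronger inhibitor than the ethynyl compound. The steps that start from the other two limit compounds cannot be read, so neither the exchange of phenyl for furan-3-yl nor that of methyl for methylamino has a size here.

Going by these compounds, it remains open whether any group on this aromatic carbon brings the series clearly below the limit, since the ethynyl compound alone carries a number and that number lies close to the limit. A thiophen-2-yl ring, a bromine atom or a longer alkyne chain at this place, or an unsubstituted amino group in place of methylamino, would be needed to say how far this position can move the read-out.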